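The source may hold more compounds than are shown below. What is called first, only, known or untested is meant among the compounds shown, and "the series" means these compounds.

- Compound 1 `COc1cc(/C=C/c2nc(Cl)cc(NC(C)C)n2)cc(OC)c1OC`: < 40000 nM, a limit
- Compound 2 `FC(F)(F)c1ccc(Nc2nc(/C=C/c3ccccc3)nc3ccsc23)cc1`: > 1000000 nM, a limit
- Compound 3 `CNc1nc(/C=C/c2ccco2)nc2ccsc12`: 811000 nM

In a functional assay on L02 cells (Homo sapiens) for inhibition, read by Griess assay, with stated times of 1 h and 24 h (on this read-out higher numbers stand for weaker inhibition and lower numbers for stronger inhibition), compound 3 gives 811000 nM, the only true number among these three results. The other two results are limits of the assay. Compound 4 `Fc1ccccc1CNc1nc(/C=C/c2ccco2)nc2ccsc12` keeps the core of compound 3 but carries 2-fluorophenyl in place of hydrogen on a saturated chain carbon bound to a nitrogen on an aromatic ring, which turns methyl into 2-fluorobenzyl (2-fluorophenyl in place of hydrogen on a saturated chain carbon bound to a nitrogen on an aromatic ring). Within the data shown here, no measured pair shows this change, so any expectation is loose. With compound 3 at 811000 nM, a move towards stronger inhibition seems more likely than one towards weaker inhibition. The estimated step is a 2.7-fold lower number from compound 3 to compound 4 (0.43 log units; beyond the scatter), a moderate one. For compound 4 the expected value is 300000 nM, with an estimated range of 60000 nM to 1000000 nM.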

Compound 4, half-maximal inhibitory concentration: > 1000000 nM
Compound 4: only a limit was reported; the forecaster's own chance of this, stated with the estimate: 25%; middle value at least 3.3-fold (0.52 log units) from the limit.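

In this assay, compound 4 gives > 1000000 nM, which is a limit and not a number. Turning methyl into 2-fluorobenzyl gives an at least 1.2-fold higher number from compound 3 to compound 4 (0.09 log units; that floor lies within the scatter), so this change on a saturated chain carbon bound to a nitrogen on an aromatic ring brought no measurable gain in inhibition, and the true size of the step stays unknown. Compound 4 therefore joins the compounds at the upper limit: the limit of > 1000000 nM in this assay, at which 2 of the 4 values shown sit.

The compounds shown leave open how a plain benzyl or an ethyl group would read in this place. They also cannot separate the part played by the fluorine from that of the phenyl ring.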